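A few compounds are considered here, and "the series" means these few. Any claim that something is new, unique, unknown or untested is made for them only; others in the source may bear on it.

Measured in a functional assay on HCT-116 cells (Homo sapiens) for cytotoxicity, read by resazurin assay, with a stated time of 48 h; on this read-out higher numbers stand for an effect only at larger amounts of compound and lower numbers for an effect already at smaller amounts:
- compound 1 `COc1ccc(S(=O)(=O)Nc2ccc(-c3nc4cc(NS(=O)(=O)c5ccc(OC)cc5)ccc4o3)cc2)cc1`: 12000 nM
- compound 2 `COc1ccc(S(=O)(=O)Nc2ccc3oc(-c4ccc(NS(=O)(=O)c5cc(F)ccc5OC)cc4)nc3c2)cc1`: 15000 nM

Compound 2, at 15000 nM, lies within the usual scatter of compound 1, at 12000 nM, so these two numbers cannot be told apart. Compound 3 `COc1ccc(S(=O)(=O)Nc2ccc3oc(-c4ccc(NC(=O)C5CCN(C(C)=O)CC5)cc4)nc3c2)cc1` has not yet been measured in this assay. It differs from compound 2 in one place, on a nitrogen on an aromatic ring, where (1-acetylpiperidin-4-yl)carbonyl enters: a group of 11 heavy atoms (8 carbon, 1 nitrogen, 2 oxygen; one six-membered non-aromatic ring with 1 hetero atom) in place of a group of 12 heavy atoms (7 carbon, 3 oxygen, 1 fluorine, 1 sulfur; one six-membered aromatic ring of carbon only), on a nitrogen on an aromatic ring. A six-membered aromatic ring of carbon only thus gives way to a six-membered non-aromatic ring with 1 hetero atom.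

Within the data shown here, only one measured step bears on this change: a 1.3-fold higher number from compound 1 to compound 2 (0.10 log units; within the scatter). That step swapped one aromatic group on a sulfonyl sulfur for another and stayed within the scatter. Among the measured compounds shown here, the present change is much larger, and no measured compound carries the entering group, so the evidence is thin. For the measured compounds named here, with no measured step pointing either way, the expected step is a 1.1-fold higher number from compound 2 to compound 3 (0.03 log units; within the scatter), which means no clear change beyond the scatter. The estimate for compound 3 is 16000 nM, with an expected range of 6000 nM to 45000 nM.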

Compound 3, half-maximal effective concentration: 15000 nM
The estimate for compound 3 lay 1.1-fold (0.03 log units) above the measured number, within the range that was stated.
By their numbers in this assay, from the lowest: compounds 1, 2 and 3 (each within the scatter of the next).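

In this assay, among these compounds, the earlier compounds only showed one aromatic group on a sulfonyl sulfur exchanged for another, whereas this result concerns a much larger change on a nitrogen on an aromatic ring. There the whole sulfonyl group, with its six-membered aromatic ring of carbon only, gives way to (1-acetylpiperidin-4-yl)carbonyl, with a six-membered non-aromatic ring, and the outcome is small both against the closest fluorinated partner (no change at the digits printed from compound 2 to compound 3 (within the scatter)) and against the original sulfonyl group (a 1.3-fold higher number from compound 1 to compound 3 (0.10 log units; within the scatter)), so at this place the read-out does not separate these two quite different kinds of group. No accompanying measurement offers an explanation for this outcome.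

From the compounds shown here alone, all three compounds stay within the scatter of one another, so it remains open whether any group at this nitrogen can move the number beyond the scatter. An amine or a carboxylic acid on the piperidine ring, or a simple acetyl group on the nitrogen in place of the whole (1-acetylpiperidin-4-yl)carbonyl, would each test that question.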